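The compounds below may be only part of what the source reports. "The series", "measured", "known", "first", "only" and "open" are said of these compounds alone.

In a functional assay on MDA-MB-435 cells (Homo sapiens) for cytotoxicity, read by MTT assay, with a stated time of 72 h (on this read-out higher numbers stand for weaker inhibition and lower numbers for stronger inhibition), compound 3, whose structure is `CN(C)CCCNc1c(C(=O)NCc2ccc(F)cc2)nc(Br)c2cccnc12`, gives 7000 nM, the lowest of the two plain numbers shown. Compound 2, with structure `O=C(NCc1ccc(F)cc1)c1nc(Br)c2cccnc2c1N1CCNCC1`, gives 8000 nM, and the gap a 1.1-fold lower number from compound 2 to compound 3 (0.06 log units; within the scatter) lies within the scatter, so these two cannot be ranked against each other. Compound 1, with structure `C[C@H](Nc1c(C(=O)NCc2ccc(F)cc2)nc(Br)c2cccnc12)c1ccccc1`, is reported only as a limit, > 20000 nM. The line the limit of > 20000 nM in this assay, at which 1 of the 3 values shown sits, marks that boundary of the assay. The steps of an at least 2.5-fold lower number from compound 1 to compound 2 (0.39 log units; beyond the scatter) and an at least 2.8-fold lower number from compound 1 to compound 3 (0.45 log units; beyond the scatter) show that swapping the 1-phenylethyl group for either a piperazin-1-yl or a 3-(dimethylamino)propyl chain gave an at least modestly lower number.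

Compound 4, with structure `CNc1c(C(=O)NCc2ccc(F)cc2)nc(Br)c2cccnc12`, differs from compound 3 by hydrogen in place of 2-(dimethylamino)ethyl on a saturated chain carbon bound to a nitrogen on an aromatic ring. Going by the values given here, none of the measured steps removes the dimethylamino tail itself, so they bear on this change only indirectly: the two compounds that carry a dimethylamino or piperazin-1-yl group sit near each other, and the chain on the ring nitrogen was the part that changed in both steps from compound 1. For compound 4 a weakening step of a 2.1-fold higher number from compound 3 to compound 4 (0.33 log units; beyond the scatter) is therefore expected, probably beyond the scatter. Compound 4 is estimated at 15000 nM, within a range from 5000 nM to 40000 nM, with a real chance that only a limit is reported.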

Compound 4, half-maximal inhibitory concentration: > 20000 nM
Compound 4: a limit, no number; the forecaster's own chance of this, stated with the estimate: 40%; middle value at least 1.3-fold (0.12 log units) away from the limit.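

In this assay, cutting the 3-(dimethylamino)propyl group on the nitrogen on the aromatic ring back to methyl gives an at least 2.8-fold higher number from compound 3 to compound 4 (0.45 log units; beyond the scatter), and putting methylamino in place of piperazin-1-yl gives an at least 2.5-fold higher number from compound 2 to compound 4 (0.39 log units; beyond the scatter). The earlier steps shown here only exchanged one large group for another, whereas these show that a bare methyl on this nitrogen does not keep the plain numbers seen with the larger amine-bearing groups, and across the four compounds the two with plain numbers carry a dimethylamino or piperazin-1-yl group, while compound 1 and compound 4, which carry neither, are reported only as limits: the limit of > 20000 nM in this assay, at which 2 of the 4 values shown sit. The step between compound 1 and compound 4 cannot be read, since both are limits, so methyl and 1-phenylethyl on this nitrogen cannot be ranked against each other.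

The compounds shown leave open how far compound 4 really lies from compound 3, and whether the dimethylamino group or the chain that carries it accounts for the step. A plain butyl chain with no amine, or a propyl chain ending in a hydroxyl group, on the same nitrogen would separate those two readings.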